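The source may report more compounds than this note shows. Statements on the series, on what has been measured and on what is new or still open speak of the compounds shown alone.

Measured so far in an ADME assay on Vero cells (Chlorocebus sabaeus) for cytotoxicity, read by MTT assay, with a stated time of 48 h; on this read-out higher numbers stand for weaker inhibition and lower numbers for stronger inhibition:
- Compound 1 `CC(C)C(=O)OC1CCC(CN2CCN(c3cc(=O)c4cc(C(F)(F)F)cc([N+](=O)[O-])c4s3)CC2)CC1`: > 64 ug/mL
- Compound 2 `CCCC(=O)OC1CCC(CN2CCN(c3cc(=O)c4cc(C(F)(F)F)cc([N+](=O)[O-])c4s3)CC2)CC1`: > 64 ug/mL
- Compound 3 `O=C(OC1CCC(CN2CCN(c3cc(=O)c4cc(C(F)(F)F)cc([N+](=O)[O-])c4s3)CC2)CC1)c1cccc(C(F)(F)F)c1`: > 64 ug/mL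

In this assay, compound 2 stands at > 64 ug/mL, which is a limit of the assay and not a number. The other two entries are limits as well, as the limit of > 64 ug/mL in this assay, at which 3 of the 3 values shown sit, records.

Compound 4 `O=c1cc(N2CCN(CC3CCC(NS(=O)(=O)c4ccccc4)CC3)CC2)sc2c([N+](=O)[O-])cc(C(F)(F)F)cc12` has not yet been measured. It carries (phenylsulfonyl)amino in place of (propylcarbonyl)oxy on a saturated ring carbon.

The nearest measured changes are a step that the two limits leave unreadable from compound 1 to compound 2 and a step that the two limits leave unreadable from compound 2 to compound 3. Among the measured compounds shown here, both alter only the group on the carbonyl carbon, neither has a readable size, and neither measures a change like the one in compound 4.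

Compound 3, with 3-(trifluoromethyl)phenyl on the carbonyl carbon, sits at > 64 ug/mL, also a limit. On that basis, no step beyond the scatter is expected in this assay, and the estimated change is a number no higher from compound 2 to compound 4 (the limit leaves the size open). A further limit is the likeliest report.

For compound 4 the estimate is 64 ug/mL, with an expected range from 30 ug/mL to 128 ug/mL.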

Compound 4, half-maximal inhibitory concentration: > 64 ug/mL
Compound 4 ended at the assay's limit (the forecaster's own chance of this, stated with the estimate: 75%); the middle value sits exactly at the limit.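

Neither step to compound 4, from compound 1 or from compound 2, can be read, since the values on both sides are limits of the assay and not numbers. The compounds shown leave open whether any of them inhibits measurably in this assay, since all rest on one value: the limit of > 64 ug/mL in this assay, at which 4 of the 4 values shown sit.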